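This account rests on a few compounds, and the source may have more. Where it says the series, first, only, none or still open, it means among the compounds named here.

Measured in a functional assay on ileum (Cavia porcellus) for inhibition; a higher number here means a weaker inhibitor, a lower number a stronger inhibitor:
- compound 1 `COC(=O)C1=C(C)NC(C)=C(C(=O)OC)C1c1c(-c2cccs2)nc2sccn12`: 110 nM
- compound 2 `COC(=O)C1=C(C)NC(C)=C(C(=O)OC)C1c1c(-c2ccsc2)nc2sccn12`: 2.3 nM

Compound 2 holds the lower of the two numbers and is the stronger inhibitor of the pair, beyond the scatter. Among the compounds with values here, the only measured step is a 48-fold lower number from compound 1 to compound 2 (1.68 log units; beyond the scatter), a large change, and the two compounds differ only in that compound 1 bears thiophen-2-yl where compound 2 bears thiophen-3-yl.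

Compound 3 `COC(=O)C1=C(C)NC(C)=C(C(=O)OC)C1c1c(-c2ccncc2)nc2sccn12` has not yet been measured in this assay. It carries pyridin-4-yl in place of thiophen-3-yl on an aromatic carbon of a five-membered aromatic ring with 2 nitrogen (pyridin-4-yl in place of thiophen-3-yl on an aromatic carbon).

The measured step bears on this change only indirectly. It shows that exchanging one aromatic ring for another can move the number a long way, but no six-membered ring has been measured. Within the data shown here, compound 2, at 2.3 nM, is the lower of only two values, so a rise seems more likely than a further fall. The expected change is an 8.7-fold higher number from compound 2 to compound 3 (0.94 log units; beyond the scatter), smaller than the measured step and toward weaker inhibition. For compound 3 the estimated value is 20 nM, with an expected range of 2.5 nM to 160 nM.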

Compound 3, half-maximal inhibitory concentration: 960 nM
The estimate for compound 3 lay 48-fold (1.68 log units) below the measured number, outside the stated range (above it).
By their numbers in this assay, from the lowest: compound 2; then compound 1; then compound 3.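

In this assay, within the data shown here, the exchange of thiophen-3-yl for pyridin-4-yl on this aromatic carbon gives a 420-fold higher number from compound 2 to compound 3 (2.62 log units; beyond the scatter), the first reading of a six-membered aromatic ring at this place, and that ring carries the highest number of the three. Set against thiophen-2-yl, pyridin-4-yl gives an 8.7-fold higher number from compound 1 to compound 3 (0.94 log units; beyond the scatter), so the order at this position, from lowest number to highest, is thiophen-3-yl, thiophen-2-yl, pyridin-4-yl, with every step beyond the scatter. Nothing available here accounts for the size of these steps.

The three compounds do not separate ring size from the identity of the hetero atom, since the exchange from thiophene to pyridine changes both at once; a phenyl group or pyridin-3-yl at this place would pull the two apart. As far as these compounds go, it also remains open whether the low number of thiophen-3-yl holds when the shared core changes elsewhere, for instance with ethyl esters in place of the methyl esters.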